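The compounds below may be only part of what the source reports. "The series", "measured", "known", "first", "only" and "open" are said of these compounds alone.

Measured compounds:
compound 1 `NC(N)=NC(=O)c1nc(Cl)c(NCC2CCCCC2)nc1N` gives 28%;
compound 2 `NC(N)=NC(=O)c1nc(Cl)c(N2CCCC2)nc1N` gives 12%;
compound 3 `NC(N)=NC(=O)c1nc(Cl)c(N2CCCCC2)nc1N` gives "not determined" (no result reported), that is, no reported result.

These three share one core and differ only in the group attached to it. In an assay for inhibition of acid-sensing ion channel 3 (Homo sapiens), read by patch clamp, tested at 1 uM (on this read-out higher numbers stand for more inhibition at the one concentration tested (going by the name of the read-out) and lower numbers for less inhibition), compound 1 and compound 2 both show modest inhibition, and their two numbers lie within the usual scatter of each other, so neither can be called stronger. Compound 3 carries a piperidin-1-yl group at that position, but no number is known for it, so it gives no fixed footing.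

Compound 4 `NC(N)=NC(=O)c1nc(Cl)c(Nc2ccccc2)nc1N` differs from compound 3 by anilino in place of piperidin-1-yl on an aromatic carbon. Going by the values given here, with no measured step in this assay to lean on, the expectation for compound 4 is a modest value in the same band as compound 1 and compound 2, with wide uncertainty. Compound 4 is estimated at 20%, between 0% and 50%.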

Compound 4, a percentage reported as inhibition, at one concentration (the size of the read-out at that concentration, not a potency): 44%
Compound 4: the middle estimate sits 24 percentage points below what was measured, and the stated range covers the measured number.
By their numbers in this assay, from the lowest: compound 2; then compound 1; then compound 4.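

In this assay the group at this position clearly moves the read-out: anilino in place of pyrrolidin-1-yl gives a number 32 percentage points higher from compound 2 to compound 4 (beyond the scatter), and phenyl in place of cyclohexylmethyl on the nitrogen gives a number 16 percentage points higher from compound 1 to compound 4 (beyond the scatter). Among these three compounds with numbers, the anilino group of compound 4 gives the most inhibition, beyond the scatter of both others. Nothing available here explains this rise. Still open, on these data alone, is whether a benzyl or pyridin-3-ylamino group in place of anilino would raise the number further or lower it.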